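The compounds below may be only part of what the source reports. "The series", "measured", "known", "first", "only" and "open" are said of these compounds alone.

- Compound 1 `COCOc1ccc(/C=C/CCCOc2cc(/C=C\c3cc(OC)c(OC)c(OC)c3)ccc2OC)cc1`: 25000 nM
- Compound 2 `COc1ccc(/C=C\c2cc(OC)c(OC)c(OC)c2)cc1OCCC/C=C/c1ccc(F)cc1`: 115000 nM

In an ADME assay on HEK293 cells (Homo sapiens) for inhibition, read by MTT assay, with a stated time of 3 days (a lower number here means a stronger inhibitor, a higher number a weaker inhibitor), compound 2 has the higher of the two numbers, at 115000 nM, so it is the weaker inhibitor of the pair. Compound 3 `COc1ccc(/C=C\c2cc(OC)c(OC)c(OC)c2)cc1OCCC/C=C/c1ccc(Cl)cc1` differs from it at one place, para to a large group on a six-membered aromatic ring of carbon only: chloro in place of fluoro on an aromatic carbon.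

Within the data shown here, only one measured step bears on this place: a 4.6-fold higher number from compound 1 to compound 2 (0.66 log units; beyond the scatter). That modest step exchanged methoxymethoxy for fluoro, and no exchange of fluoro for chloro has been measured. A smaller step than that one is therefore expected, with only a weak lean towards a lower number. The estimated change is a 1.4-fold lower number from compound 2 to compound 3 (0.13 log units; within the scatter), which is not expected to lie clearly beyond the scatter. For compound 3, the expected value is 85000 nM, with an estimated range of 30000 nM to 200000 nM.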

Compound 3, half-maximal inhibitory concentration: 111000 nM
The estimate for compound 3 lay 1.3-fold (0.12 log units) below the measured number; the range from low to high includes it.
By their numbers in this assay, from the lowest: compound 1; then compounds 3 and 2 (each within the scatter of the next).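

Among these compounds, replacing fluoro with chloro at this place, on the aromatic carbon para to a large group, is the first exchange of one halogen for another here, and in this assay it gives a 1.0-fold lower number from compound 2 to compound 3 (0.02 log units; within the scatter), so the two halogens cannot be told apart in this assay. The step from methoxymethoxy to chloro, a 4.4-fold higher number from compound 1 to compound 3 (0.65 log units; beyond the scatter), is of the same modest size as the step to fluoro, a 4.6-fold higher number from compound 1 to compound 2 (0.66 log units; beyond the scatter), so both halogens stand apart from methoxymethoxy in the same direction. Nothing available accounts for either the match between the halogens or their gap from methoxymethoxy.

On these data alone, it remains open whether a hydroxy group, an amine or a carboxylic acid at this place would read closer to compound 1 or to the halogens. The compounds shown also leave open whether a longer chain would preserve the match between fluoro and chloro.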